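Methyl on the amide nitrogen: a small step forecast

A few compounds are considered here, and "the series" means these few. Any claim that something is new, unique, unknown or untested is made for them only; others in the source may bear on it.

Of the compounds shown here, three have been measured in an assay on isolated protein for inhibition of Amine oxidase [flavin-containing] A (Homo sapiens); on this read-out higher numbers stand for weaker inhibition and lower numbers for stronger inhibition. Compound 1, `Cn1c(CNc2ccccc2)cc2ccccc21`, gives 10000000 nM. Compound 2, `CN(Cc1cc2ccccc2n1C)c1ccccc1`, carries methyl in place of hydrogen on a nitrogen on an aromatic ring and gives 6000000 nM; the resulting step is a 1.7-fold lower number from compound 1 to compound 2 (0.22 log units; within the scatter). Compound 3, `O=C(NCCCCc1ccccc1)c1ccc[nH]1`, has a different core; the difference between the two cores is not broken down here. In this assay compound 3 gives 55000000 nM, the highest of the three numbers, with the gap to compound 1 and to compound 2 each beyond the scatter.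

The unmeasured compound 4, `CN(CCCCc1ccccc1)C(=O)c1ccc[nH]1`, is derived from compound 3 by methyl in place of hydrogen on an amide-type nitrogen. For the measured compounds named here, this is the same kind of change as the one from compound 1 to compound 2, but not the same: there the nitrogen sits on an aromatic ring with an aromatic carbon and a saturated chain carbon as its other neighbours, whereas here it is an amide-type nitrogen whose other neighbours are a carbonyl carbon and a saturated chain carbon.

Going by the values given here, the only guide is the step of a 1.7-fold lower number from compound 1 to compound 2 (0.22 log units; within the scatter), which stayed within the scatter. The expected step in this assay is a 1.4-fold lower number from compound 3 to compound 4 (0.14 log units; within the scatter), placed beside the earlier one because the step of a 1.7-fold lower number from compound 1 to compound 2 (0.22 log units; within the scatter) was small. Compound 4 is therefore expected to give about 40000000 nM, with the estimate ranging from 10000000 nM to 150000000 nM.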

Compound 4, inhibition constant: 89900000 nM
The estimate for compound 4 lay 2.2-fold (0.35 log units) below the measured number; low and high end bracket the measured number.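

In this assay, methyl in place of hydrogen on an amide-type nitrogen gave a 1.6-fold higher number from compound 3 to compound 4 (0.21 log units; within the scatter), so on this core the change leaves the number within the usual scatter. Taken together, the results show that the step measured on one core did not carry over unchanged to the other, since the two steps differ by more than the scatter of two such steps: the same change on two cores in this assay, a 1.7-fold lower number (0.22 log units; within the scatter) from compound 1 to compound 2 and a 1.6-fold higher number (0.21 log units; within the scatter) from compound 3 to compound 4, 2.7-fold (0.44 log units) apart, beyond the scatter of two such steps

What this does not show is why the steps differ, as the two changes sit on different kinds of nitrogen as well as on different cores, and these two pairs cannot separate the one from the other. The compounds shown leave open whether ethyl or a longer chain in place of hydrogen on the amide-type nitrogen would move the number in this assay beyond the scatter. They also leave open how the same methyl step would behave on a core carrying an amine or a carboxylic acid, and so whether either measured step would hold on a third core.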